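Hydroxy in Place of Acetyl: Expected Cytotoxicity Outcome

The compounds below may be only part of what the source reports. "The series", "measured", "known", "first", "only" and "open" are said of these compounds alone.

Compound 1 `CC(=O)c1ccc(NC(=O)Nc2cc(C)nc3ccccc23)cc1` was tested in an ADME assay on Raji cells (Homo sapiens) for cytotoxicity, with a stated time of 72 h; a higher number here means that more compound is needed for the effect, a lower number that less compound is needed. In this assay compound 1 gives only the limit > 25000 nM, not a number. Compound 2 `Cc1cc(NC(=O)Nc2cccc(C(N)=O)c2)c2ccccc2n1` likewise reaches only the limit > 25000 nM in this assay. Within the data shown here, both values sit at the limit of > 25000 nM in this assay, at which 2 of the 2 values shown sit, so compound 1 stands level with the one other value shown. Compound 3 `Cc1cc(NC(=O)Nc2ccc(O)cc2)c2ccccc2n1` differs from compound 1 by hydroxy in place of acetyl on an aromatic carbon. Among the measured compounds shown here, no measured step of this kind exists. The step that the limit leaves unreadable from compound 1 to compound 3 is expected to stay within the scatter. Compound 3 is estimated at 30000 nM, between 10000 nM and 100000 nM.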

Compound 3, half-maximal effective concentration: > 25000 nM
Compound 3 ended at the assay's limit; the forecaster's own chance of this, stated with the estimate: 85%; the middle value does not contradict the limit.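

In this assay compound 1 and compound 3 each give only a limit, not a number, so no step between them can be read: the limit of > 25000 nM in this assay, at which 3 of the 3 values shown sit.

The compounds shown leave open whether hydroxy in place of acetyl alters cytotoxicity at all.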